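From tert-butyl to 2-fluorophenyl in compound 4

The compounds below may be only part of what the source reports. "The series", "measured", "known", "first", "only" and "open" are said of these compounds alone.

In a functional assay on a cell-free system (plasma, Homo sapiens), with a stated time of 3 min (a lower number here means a stronger inhibitor, a higher number a weaker inhibitor), compound 3 `CC(C)(C)[C@@H](O)C(=O)N1[C@H](C(=O)NCc2cc(Cl)ccc2-n2cnnn2)C[C@@H]2C[C@@H]21` gives 1500 nM. Compound 1 `O=C(NCc1cc(Cl)ccc1-n1cnnn1)[C@@H]1C[C@@H]2C[C@@H]2N1C(=O)[C@H](O)CC1CC1` gives 1700 nM, within the scatter of compound 3, while compound 2 `CC(C)(C)OC[C@@H](O)C(=O)N1[C@H](C(=O)NCc2cc(Cl)ccc2-n2cnnn2)C[C@@H]2C[C@@H]21` gives 500 nM, so compound 3 sits on the weaker side of compound 2.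

Compound 4 `O=C(NCc1cc(Cl)ccc1-n1cnnn1)[C@@H]1C[C@@H]2C[C@@H]2N1C(=O)[C@H](O)c1ccccc1F` differs from compound 3 in one group, with 2-fluorophenyl in place of tert-butyl on a saturated chain carbon bound to a carbonyl carbon and an oxygen on a saturated carbon.

The measured steps all change the group at this same place. They are a 1.1-fold lower number from compound 1 to compound 3 (0.05 log units; within the scatter), a 3.4-fold lower number from compound 1 to compound 2 (0.53 log units; beyond the scatter) and a 3.0-fold higher number from compound 2 to compound 3 (0.48 log units; beyond the scatter). Among the compounds with values here, none of the measured compounds has an aromatic ring there, so the direction is uncertain. A modest step is expected, and a 3.4-fold lower number from compound 1 to compound 2 (0.53 log units; beyond the scatter) gives a slight lean towards a lower number.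

The expected change is a 1.9-fold lower number from compound 3 to compound 4 (0.27 log units; within the scatter). For compound 4 the estimated value is 800 nM, with an expected range from 200 nM to 3000 nM.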

Compound 4, half-maximal inhibitory concentration: 770 nM
Compound 4: middle estimate off by 1.0-fold (0.02 log units), on the high side, and the stated range covers the measured number.
By their numbers in this assay, from the lowest: compounds 2, 4, 3 and 1 (each within the scatter of the next, the first and the last beyond it).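

Within the data shown here, an aromatic ring can sit at this position without loss in this assay, something none of the earlier compounds could show. Placing 2-fluorophenyl on this carbon gives a 1.9-fold lower number from compound 3 to compound 4 (0.29 log units; within the scatter) and a 1.5-fold higher number from compound 2 to compound 4 (0.19 log units; within the scatter), so compound 4 cannot be told apart from compound 3 or compound 2, whereas a 2.2-fold lower number from compound 1 to compound 4 (0.34 log units; beyond the scatter) is a modest step that clears the scatter, with cyclopropylmethyl as the group replaced. Nothing available here bears on why these numbers come out as they do.

On these data alone, whether plain phenyl would match 2-fluorophenyl, and so what the fluorine itself contributes, stays open. So does the outcome with a pyridyl ring or an amine at this place.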